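A few compounds are considered here, and "the series" means these few. Any claim that something is new, unique, unknown or untested is made for them only; others in the source may bear on it.

Measured in a functional assay on HCT-116 cells (Homo sapiens) for antiproliferative activity, read by MTT assay, with a stated time of 48 h; on this read-out higher numbers stand for weaker inhibition and lower numbers for stronger inhibition:
- Compound 1 `CCOc1cc(-c2ccc3[nH]ccc3c2)cn2c(-c3cc(OC)c(OC)c(OC)c3)nnc12`: 374 nM.
- Compound 2 `COc1cc(-c2nnc3c(OC)cc(-c4ccc5[nH]cc(C=O)c5c4)cn23)cc(OC)c1OC`: > 10000 nM, which is a limit of the assay and not a number.
- Compound 3 `COc1cc(-c2nnc3c(OC)cc(-c4ccc5c(ccn5C)c4)cn23)cc(OC)c1OC`: 33 nM.

In this assay, compound 1 gives 374 nM and compound 3 gives 33 nM. Of the two exact numbers, that of compound 3 is the lower, and the gap lies beyond the scatter.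

Compound 4 `COc1cc(-c2nnc3c(OC4CC4)cc(-c4ccc5c(ccn5C)c4)cn23)cc(OC)c1OC` keeps everything in compound 3 except for cyclopropyl in place of methyl on an oxygen on an aromatic ring.

Among the measured compounds shown here, the only measured step between compounds differing in one place is an at least 300-fold lower number from compound 2 to compound 3 (2.48 log units; beyond the scatter). It concerns 1-methyl-1H-indol-5-yl in place of 3-formyl-1H-indol-5-yl on an aromatic carbon, not the group on the oxygen, and it starts from the limit of > 10000 nM in this assay, at which 1 of the 3 values shown sits. For the measured compounds named here, it therefore says little about the size of the present change, and no measured step alters the group on this oxygen alone.

A much smaller move is expected than that large step, most likely toward weaker inhibition. The expected step is a 2.7-fold higher number from compound 3 to compound 4 (0.44 log units; beyond the scatter). For compound 4 the estimated value is 90 nM, with an expected range of 25 nM to 350 nM.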

Compound 4, half-maximal inhibitory concentration: 135 nM
The estimate for compound 4 lay 1.5-fold (0.18 log units) below the measured number; low and high end bracket the measured number.
By their numbers in this assay, from the lowest: compound 3; then compound 4; then compound 1. At a limit, above all of these: compound 2.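

Working notes on the group on this oxygen: in this assay, the change from methoxy to cyclopropyloxy gives a 4.1-fold higher number from compound 3 to compound 4 (0.61 log units; beyond the scatter), the first reading of this position with the rest of the molecule held constant. The position is therefore sensitive to the group it carries, and within this pair the methyl is preferred over the cyclopropyl, though compound 4 still gives an exact number of 135 nM, so the three-membered ring is accommodated with a modest loss rather than a collapse of activity. Among the compounds shown here, nothing measured so far accounts for this step.

For the compounds shown here, only two groups on this oxygen can be compared directly with the 1-methyl-1H-indol-5-yl group held in place, so the pair cannot show whether the shift follows the number of carbons or the ring itself, and a straight propoxy chain or an isopropoxy group would be needed to separate the two. Also open, going by these compounds, is how this position responds to groups of another kind, such as a hydroxyl in place of the methoxy or an ether chain ending in an amine or a carboxylic acid.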